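This account rests on a few compounds, and the source may have more. Where it says the series, first, only, none or still open, it means among the compounds named here.

Three compounds have been measured in a functional assay on MCF7 cells (Homo sapiens) for cytotoxicity, read by MTT assay, with a stated time of 48 h; a higher number here means a weaker inhibitor, a lower number a stronger inhibitor:

Compound 1 `CCCCCCCCCCCCCCCCCCNC(=O)[C@@H](N)[C@@H](C)O`: 27400 nM
Compound 2 `CCCCCCCCNC(=O)[C@@H](NC(=O)c1ccco1)[C@@H](C)O`: 91800 nM
Compound 3 `CCCCCCCCNC(=O)[C@@H](NC(=O)c1nccc2ccccc12)[C@@H](C)O`: 63200 nM

Compound 2 has the highest number of the three, but compound 3 sits within the scatter of it, so the two cannot be told apart; compound 1 lies lower by more than the scatter. Compound 4 `CCCCCCCCNC(=O)[C@@H](NC(=O)/C=C/c1ccccc1)[C@@H](C)O` differs from compound 2 by one change: 2-phenylethenyl in place of furan-2-yl on a carbonyl carbon. Within the data shown here, no measured pair shows this exact swap, so nothing indicates whether it helps or hurts. The step from compound 2 to compound 4 is expected to be small, a 1.3-fold lower number from compound 2 to compound 4 (0.12 log units; within the scatter), with no clear direction beyond the scatter. Compound 4 is therefore estimated at 70000 nM, likely between 25000 nM and 200000 nM in this assay.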

Compound 4, half-maximal inhibitory concentration: 35100 nM
Compound 4: middle estimate off by 2.0-fold (0.30 log units), on the high side, within the range that was stated.
By their numbers in this assay, from the lowest: compounds 1, 4, 3 and 2 (each within the scatter of the next, the first and the last beyond it).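

Among these compounds, putting 2-phenylethenyl in place of furan-2-yl on this carbonyl carbon gives a 2.6-fold lower number from compound 2 to compound 4 (0.42 log units; beyond the scatter) in this assay and this modest step is the only single change here that can be read. It shows that the number at this position depends on the group attached and that furan-2-yl can be replaced without losing activity. No measurement offers a reason for the step.

Going by these compounds, whether the double bond outside the ring matters remains open, and a phenyl or 2-phenylethyl group would test this. So does whether the step would hold with a longer chain on the amide nitrogen.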